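Aryl variation on the side chain of compound 1

The source may report more compounds than this note shows. Statements on the series, on what has been measured and on what is new or still open speak of the compounds shown alone.

Measured compounds:
compound 1 `Cc1ccc(C)c(OCc2nnc(C(=O)Nc3ccc(CCC(=O)O)cc3)s2)c1`: 1530 nM
compound 2 `O=C(O)CCc1ccc(NC(=O)c2nnc(COc3cccc(Cl)c3)s2)cc1`: 1570 nM

In a functional assay on CHO cells for agonist activity at Free fatty acid receptor 1 (Homo sapiens), read by FLIPR and calcium flux, tested at 1 uM (on this read-out lower numbers stand for an effect already at smaller amounts and higher numbers for an effect only at larger amounts of compound), compound 1 gives 1530 nM and compound 2 gives 1570 nM. Among the measured compounds shown here, compound 1 has the lower of the two numbers, but its only neighbour, compound 2, lies within the scatter of it: a 1.0-fold higher number from compound 1 to compound 2 (0.01 log units; within the scatter) for 3-chlorophenyl in place of 2,5-dimethylphenyl on an oxygen on a saturated carbon.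

Compound 3 `O=C(O)CCc1ccc(NC(=O)c2nnc(Cc3cccc(F)c3)s2)cc1` has not been measured. Relative to compound 1 the change is 3-fluorophenyl in place of 2,5-dimethylphenoxy on a saturated chain carbon bound to an aromatic carbon. For the measured compounds named here, the one measured step that bears on it, a 1.0-fold higher number from compound 1 to compound 2 (0.01 log units; within the scatter), exchanged one aryl group for another with the oxygen kept and stayed within the scatter. Removal of the oxygen has no measured counterpart in this set, so the expectation rests on that single step alone. A step of a 1.2-fold higher number from compound 1 to compound 3 (0.07 log units; within the scatter) is expected, within the scatter. Compound 3 is estimated at 1800 nM, with a range from 700 nM to 4500 nM.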

Compound 3, half-maximal effective concentration: 5020 nM
Compound 3: middle estimate off by 2.8-fold (0.45 log units), on the low side; measured number outside the range, above it.
By their numbers in this assay, from the lowest: compounds 1 and 2 (each within the scatter of the next); then compound 3.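

Compound 1 and compound 2 showed that the aryl group on the oxygen could differ with the number staying within the scatter, but the position is not indifferent to every change: in this assay there is a 3.3-fold higher number from compound 1 to compound 3 (0.52 log units; beyond the scatter) and likewise a 3.2-fold higher number from compound 2 to compound 3 (0.50 log units; beyond the scatter), both modest and beyond the scatter. Compound 3 has 3-fluorophenyl directly on the saturated chain carbon, so it differs from both neighbours in the oxygen as well as in the ring substituents, and these steps cannot divide their size between the two. Nothing on hand accounts for these steps.

Still open, from the compounds shown here alone, is whether the oxygen itself matters, which 3-fluorophenoxy on the same carbon would test. Also open, going by these compounds, is how an amine nitrogen or sulfur in place of that oxygen, or a longer chain, would read in this assay.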